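Aryl replacement on the shared core: compound 3 to compound 4

The source may hold more compounds than are shown below. What is called first, only, known or untested is meant among the compounds shown, and "the series" means these compounds.

Compound 3, `COc1ccc(-c2cc3nccc(-c4cc(OC)c(OC)c(OC)c4)n3n2)cc1F`, carries a 3-fluoro-4-methoxyphenyl on the shared core. In a functional assay on HeLa cells (Homo sapiens) for inhibition, read by CCK-8 assay, with a stated time of 48 h (on this read-out lower numbers stand for stronger inhibition and higher numbers for weaker inhibition), compound 3 gives 236 nM, the lowest of the two numbers in hand. Compound 2, `COc1cc(-c2ccnc3cc(-c4ccc(C(C)=O)cc4)nn23)cc(OC)c1OC`, gives 1810 nM in this assay. Compound 1, `COc1ccc(-c2cc3nccc(-c4cc(OC)c(OC)c(OC)c4)n3n2)cc1[N+](=O)[O-]`, reaches only a limit of this assay, > 10000 nM; that it is a limit is recorded in the limit of > 10000 nM in this assay, at which 1 of the 3 values shown sits. Both measured steps alter the same position of the core: an at least 42-fold lower number from compound 1 to compound 3 (1.62 log units; beyond the scatter), starting from a limit, and a 7.7-fold lower number from compound 2 to compound 3 (0.88 log units; beyond the scatter). The group at this position therefore moves the read-out strongly. Compound 4, `COc1cc(-c2ccnc3cc(-c4ccc5cnn(C)c5c4)nn23)cc(OC)c1OC`, is not yet measured; it differs from compound 3 as 1-methyl-1H-indazol-6-yl in place of 3-fluoro-4-methoxyphenyl on an aromatic carbon. Within the data shown here, no measured step brings in a 1-methyl-1H-indazol-6-yl or anything like it, so the direction is open; the two steps show only that a swap here can shift the number by a modest to large amount. Taking the 3-fluoro-4-methoxyphenyl as the best of the groups seen so far, compound 4 is expected at 500 nM, with a range from 150 nM to 2500 nM. The step of a 2.1-fold higher number from compound 3 to compound 4 (0.33 log units; beyond the scatter) is thus expected to be a modest rise.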

Compound 4, half-maximal inhibitory concentration: 97 nM
For compound 4 the middle estimate is 5.2-fold (0.71 log units) above the measured one; the whole stated range lies above it.
By their numbers in this assay, from the lowest: compound 4; then compound 3; then compound 2. At a limit, above all of these: compound 1.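

Replacing the 3-fluoro-4-methoxyphenyl with 1-methyl-1H-indazol-6-yl gives a 2.4-fold lower number from compound 3 to compound 4 (0.39 log units; beyond the scatter), so a substituted single phenyl ring is not needed at this position, and a group with a five-membered aromatic ring fused to a six-membered one is accepted. Among these compounds, measured against the 4-acetylphenyl, the same group gives a 19-fold lower number from compound 2 to compound 4 (1.27 log units; beyond the scatter), which leaves compound 4 with the lowest number so far. Nothing in the data accounts for this gain.

As far as these compounds go, it remains open how the read-out responds at this position to an unmethylated 1H-indazol-6-yl, a benzimidazole or an aminophenyl. Also open, from the compounds shown here alone, is whether the gain persists if the trimethoxyphenyl group shared by all four compounds is replaced.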